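The compounds below may be only part of what the source reports. "The series", "measured", "known", "first", "only" and "open" are said of these compounds alone.

Measured compounds:
- compound 1, `COc1ccc(SCc2ccc(C(=O)Nc3ccccc3N)cc2)cc1`, in a functional assay on HCT-116 cells (Homo sapiens) for inhibition, read by CCK-8 assay, with a stated time of 72 h, tested at 8 uM (on this read-out lower numbers stand for less inhibition of growth and higher numbers for more inhibition of growth at the one concentration tested), compound 1 gives 90.1%
- compound 2, `Cc1ccc(SCc2ccc(C(=O)Nc3ccccc3N)cc2)cc1`, compound 2 gives 84%
- compound 3, `Cc1cc(C)cc(SCc2ccc(C(=O)Nc3ccccc3N)cc2)c1`, compound 3 gives 72.9%

Compound 3 stands lowest of the three: it sits a number 11.1 percentage points lower from compound 2 to compound 3 (beyond the scatter) and a number 17.2 percentage points lower from compound 1 to compound 3 (beyond the scatter), both beyond the scatter. Compound 4, `Nc1ccccc1NC(=O)c1ccc(CSc2ccc(Cl)cc2)cc1`, differs from compound 3 by 4-chlorophenyl in place of 3,5-dimethylphenyl on a sulfur. For the measured compounds named here, the steps that bear on this are the two that brought the 3,5-dimethylphenyl in, a number 17.2 percentage points lower from compound 1 to compound 3 (beyond the scatter) and a number 11.1 percentage points lower from compound 2 to compound 3 (beyond the scatter), each a modest loss; the change between the two single-substituted phenyls, a number 6.1 percentage points lower from compound 1 to compound 2 (within the scatter), stayed within the scatter. Returning to a single substituent on the phenyl is therefore expected to recover a modest amount of growth inhibition in this assay, and compound 4 is estimated at 82%, between 70% and 92%, an expected a number 9.1 percentage points higher from compound 3 to compound 4 (within the scatter).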

Compound 4, percent growth inhibition at one concentration: 76.6%
Compound 4: the middle estimate sits 5.4 percentage points above what was measured, within the range that was stated.
By their numbers in this assay, from the lowest: compounds 3, 4, 2 and 1 (each within the scatter of the next, the first and the last beyond it).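

In this assay the 4-chlorophenyl on the sulfur gives a number 3.7 percentage points higher from compound 3 to compound 4 (within the scatter) and so does not clearly separate from the 3,5-dimethylphenyl. Chloro in place of methyl gives a number 7.4 percentage points lower from compound 2 to compound 4 (within the scatter) and chloro in place of methoxy gives a number 13.5 percentage points lower from compound 1 to compound 4 (beyond the scatter) and so, among these single substituents, only the step from methoxy to chloro exceeds the scatter. No measurement shown here explains these steps. Left open is how an amine or a carboxylic acid in place of the chloro would read on this phenyl.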